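Series notes: anilino change from compound 2 to compound 3

This account rests on a few compounds, and the source may have more. Where it says the series, first, only, none or still open, it means among the compounds named here.

Among the measured compounds shown here, compound 2 `COc1ccc(Nc2nc3ccccc3nc2S(=O)(=O)c2ccc(F)cc2)cc1` holds the highest of the two numbers measured so far: in a functional assay on PC-3 cells (Homo sapiens) for cytotoxicity, read by MTT assay, with a stated time of 72 h (a higher number here means a weaker inhibitor, a lower number a stronger inhibitor), compound 2 gives 4330 nM. Compound 1 `Nc1cccc(Nc2nc3ccccc3nc2S(=O)(=O)c2ccccc2)c1` differs from it at two places; in this assay compound 1 gives 2150 nM, a number within the scatter of compound 2, so nothing is read into their order. Compound 3 `Nc1cccc(Nc2nc3ccccc3nc2S(=O)(=O)c2ccc(F)cc2)c1` awaits measurement. Relative to compound 2 the change is 3-aminophenyl in place of 4-methoxyphenyl on a nitrogen on an aromatic ring, so compound 3 carries the 3-aminophenyl of compound 1 on the sulfone-bearing core of compound 2. For the measured compounds named here, no single-point step between measured compounds exists for this pair, so the expected step rests on compound 1 alone, whose 2150 nM lies within the scatter of compound 2. The step from compound 2 to compound 3 is expected to be a 1.7-fold lower number from compound 2 to compound 3 (0.22 log units; within the scatter), a modest move toward a lower number if any. For compound 3 the estimate in this assay is 2600 nM, with a range from 1000 nM to 7000 nM.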

Compound 3, half-maximal inhibitory concentration: 1980 nM
The estimate for compound 3 lay 1.3-fold (0.12 log units) above the measured number; low and high end bracket the measured number.
By their numbers in this assay, from the lowest: compounds 3, 1 and 2 (each within the scatter of the next, the first and the last beyond it).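

In this assay, among the compounds shown here, 3-aminophenyl in place of 4-methoxyphenyl on a nitrogen on an aromatic ring gives a 2.2-fold lower number from compound 2 to compound 3 (0.34 log units; beyond the scatter), the first reading of this position with the rest of the molecule held constant, and a modest one. With 3-aminophenyl held constant, fluoro in place of hydrogen on an aromatic carbon gives a 1.1-fold lower number from compound 1 to compound 3 (0.04 log units; within the scatter), so this assay cannot tell the fluoro and hydrogen compounds apart. No supporting data on hand bear on the origin of either step.

The anilino step exchanges the whole substituted ring, leaving open whether gaining the amine, losing the methoxy group or both carry it. An unsubstituted phenyl, or a hydroxyl or dimethylamino group in place of the amine, would help separate these readings.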